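The source may hold more compounds than are shown below. What is called first, only, known or untested is meant among the compounds shown, and "the series" means these compounds.

Compound 1 `N#C[C@@H]1CCCN1C(=O)[C@@H]1C[C@H](CO)CN1`: 64% in an assay on the whole organism (plasma, strain Sprague-Dawley) for inhibition of Dipeptidyl peptidase 4 (Rattus norvegicus), with a stated time of 6 h, at a dose of 1 mg/kg by the oral route; on this read-out higher numbers stand for more inhibition at the one dose given (going by the name of the read-out) and lower numbers for less inhibition
Compound 2 `CCCNC(=O)[C@@H]1CN[C@H](C(=O)N2CCC[C@H]2C#N)C1`: 59%
Compound 3 `CCN(C)C(=O)[C@@H]1CN[C@H](C(=O)N2CCC[C@H]2C#N)C1`: 71%

Compound 3 holds the highest number of the three in this assay. Its separation from compound 1, a number 7 percentage points higher from compound 1 to compound 3 (within the scatter), lies within the scatter, so those two cannot be ordered against each other; only its separation from compound 2, a number 12 percentage points higher from compound 2 to compound 3 (beyond the scatter), is beyond the scatter and counts as a modest gain.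

Compound 4 `CNC(=O)[C@@H]1CN[C@H](C(=O)N2CCC[C@H]2C#N)C1` differs from compound 3 in one place: hydrogen in place of ethyl on an amide-type nitrogen. Within the data shown here, two measured steps touch the same part of the molecule. The change of the amide substituents in a number 12 percentage points higher from compound 2 to compound 3 (beyond the scatter) gave a modest rise, whereas the exchanges of hydroxymethyl for carbamoyl groups, a number 5 percentage points lower from compound 1 to compound 2 (within the scatter) and a number 7 percentage points higher from compound 1 to compound 3 (within the scatter), stayed within the scatter. Among the measured compounds shown here, no measured step removes an ethyl from the amide nitrogen, so the direction rests on analogy alone. For the measured compounds named here, since the one step beyond the scatter, a number 12 percentage points higher from compound 2 to compound 3 (beyond the scatter), shows that the amide substituents can matter, a small loss is expected, a number 7 percentage points lower from compound 3 to compound 4 (within the scatter), most likely within the scatter. Compound 4 is therefore estimated at 64%, within a range from 50% to 78%.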

Compound 4, a percentage reported as inhibition, in the whole organism at one dose (the size of the read-out at that dose, not a potency): 75%
The estimate for compound 4 lay 11 percentage points below the measured number; measured number inside the range.
By their numbers in this assay, from the lowest: compounds 2, 1, 3 and 4 (each within the scatter of the next, the first and the last beyond it).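

In this assay, taking the ethyl off the amide-type nitrogen leaves the number within the scatter, a number 4 percentage points higher from compound 3 to compound 4 (within the scatter), so at this position the ethyl(methyl)carbamoyl and methylcarbamoyl groups cannot be told apart. Compound 2 and compound 4 both keep the amide hydrogen and differ only in the chain on that nitrogen, yet a number 16 percentage points higher from compound 2 to compound 4 (beyond the scatter) is beyond the scatter, so the amide hydrogen alone does not set the number and the propyl and methyl groups are separated here. Methylcarbamoyl is also the only one of the three carbamoyl groups whose exchange for hydroxymethyl on the saturated ring carbon goes beyond the scatter, a number 11 percentage points higher from compound 1 to compound 4 (beyond the scatter), although this gain remains modest, and no available evidence accounts for any of these differences.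

As far as these compounds go, it remains open where the unsubstituted carbamoyl group, a dimethylcarbamoyl group, a carboxylic acid or an ethylcarbamoyl group would fall on this ring carbon, the last of which would show how the number runs between methyl and propyl. These compounds are compared at a single dose and a single time, so the numbers leave their potency and the time course of inhibition open.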